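The source may hold more compounds than are shown below. What is called first, only, known or untested is meant among the compounds shown, and "the series" means these compounds.

Of the compounds shown here, three sharing one urea core have so far been measured in an ADME assay on the whole organism with Oryza sativa as the target, tested at 1 uM; a higher number here means a weaker effect of the compound at the concentration tested, a lower number a stronger effect. Compound 1 `Cc1cccc(NC(=O)N[C@H](C)c2ccccc2)c1` gives 98%, compound 2 `CCc1cccc(NC(=O)N[C@H](C)c2ccccc2)c1` gives 71%, and compound 3 `CCOC(=O)c1cccc(NC(=O)N[C@H](C)c2ccccc2)c1` gives 94%. On these three numbers compound 3 stands second highest; its nearest neighbour is compound 1, and its furthest is compound 2. The measured steps fix the spacing: a number 4 percentage points lower from compound 1 to compound 3 (within the scatter), whereas a number 23 percentage points higher from compound 2 to compound 3 (beyond the scatter), and a number 27 percentage points lower from compound 1 to compound 2 (beyond the scatter).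

Compound 4 `C[C@@H](NC(=O)Nc1cccc(F)c1)c1ccccc1` is not yet measured. It differs from compound 3 in one place: fluoro in place of ethoxycarbonyl on an aromatic carbon. The entering group sits on an aromatic carbon of a six-membered aromatic ring of carbon only, meta to a large group.

Within the data shown here, two measured steps concern the same ethoxycarbonyl group and therefore bear on this change. Exchanging it for methyl, a number 4 percentage points lower from compound 1 to compound 3 (within the scatter), stayed within the scatter, while exchanging it for ethyl, a number 23 percentage points higher from compound 2 to compound 3 (beyond the scatter), gave a modest step. Among the measured compounds shown here, no measured step introduces fluoro, so the direction rests on the ethoxycarbonyl-for-methyl comparison alone. Compound 4 is therefore expected to show no step beyond the scatter, a number 4 percentage points lower from compound 3 to compound 4 (within the scatter), and its value in this assay is estimated at 90%, within a range of 70% to 100%.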

Compound 4, a percentage reported as activity, at one concentration (the size of the read-out at that concentration, not a potency): 95%
Compound 4: the middle estimate sits 5 percentage points below what was measured; measured number inside the range.
By their numbers in this assay, from the lowest: compound 2; then compounds 3, 4 and 1 (each within the scatter of the next).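

Fluoro, with its 1 heavy atom, takes the place of the 5 heavy atoms and 2 hydrogen-bond acceptors of ethoxycarbonyl on this aromatic carbon, giving a number 1 percentage points higher from compound 3 to compound 4 (within the scatter) in this assay and showing that the read-out at this position does not follow the size of the group or its acceptor count across these two compounds. The exchange of methyl for fluoro at the same place gives a number 3 percentage points lower from compound 1 to compound 4 (within the scatter) as well, so methyl, ethoxycarbonyl and fluoro form one group in these numbers, while ethyl alone stands apart, with a number 24 percentage points higher from compound 2 to compound 4 (beyond the scatter) for the change from ethyl to fluoro. Nothing available explains why ethyl alone differs from the other three groups.

As far as these compounds go, whether the lower number belongs to ethyl only or extends to a longer chain such as propyl remains open, as does the reading for an amine or a carboxylic acid on this carbon. All four compounds keep the rest of the shared core unchanged, so these results speak for this one aromatic carbon alone.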